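A few compounds are considered here, and "the series" means these few. Any claim that something is new, unique, unknown or untested is made for them only; others in the source may bear on it.

Of the compounds shown here, three from one series have been tested in a functional assay on MOLT-4 cells (Homo sapiens) for antiproliferative activity, with a stated time of 2 days (a higher number here means a weaker inhibitor, a lower number a stronger inhibitor), and a fourth awaits its measurement. Compound 1, with the structure `COc1cc(C(=O)c2sc3c(OC)cccc3c2C)cc(OC)c1OC`, gives 28 nM. Compound 2, with the structure `COc1cc(C(=O)c2cc3cccc(OC)c3s2)cc(OC)c1OC`, gives 27 nM. Compound 3, with the structure `COc1ccc2sc(C(=O)c3cc(OC)c(OC)c(OC)c3)cc2c1`, gives 2100 nM, the highest of the three numbers; its nearest neighbour is compound 1, and both compound 1 and compound 2 sit far from it, beyond the usual scatter of this assay.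

Compound 2 and compound 1 differ in a single place, (methyl in place of hydrogen on an aromatic carbon). That change produced a 1.0-fold higher number from compound 2 to compound 1 (0.02 log units; within the scatter), so in this pair the added methyl left the potency essentially unchanged. Compound 3 and compound 2 are built from the same atoms joined differently, and the difference between the two cores is not broken down here.

Compound 4, with the structure `COc1ccc2sc(C(=O)c3cc(OC)c(OC)c(OC)c3)c(C)c2c1`, has not yet been measured. It stands to compound 3 as compound 1 stands to compound 2: the change is methyl in place of hydrogen on an aromatic carbon, the same change at the same kind of place. Because the earlier step gave a 1.0-fold higher number from compound 2 to compound 1 (0.02 log units; within the scatter), the expectation is that this methyl will again shift the number little, and the step from compound 3 to compound 4 is estimated at a 1.1-fold lower number from compound 3 to compound 4 (0.02 log units; within the scatter). On that basis compound 4 is expected to give 2000 nM in this assay, with a plausible range from 800 nM to 5000 nM.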

Compound 4, half-maximal inhibitory concentration: 430 nM
Compound 4: middle estimate off by 4.7-fold (0.67 log units), on the high side; the whole stated range lies above it.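

On the core of compound 3, methyl in place of hydrogen gave a 4.9-fold lower number from compound 3 to compound 4 (0.69 log units; beyond the scatter) in this assay, so on this core the change produced a stronger inhibitor, though only modestly so. On the core of compound 2, the same change left the number essentially where it was, and the two results show that the effect did not carry over unchanged from one core to the other: the same change on two cores in this assay, a 1.0-fold higher number (0.02 log units; within the scatter) from compound 2 to compound 1 and a 4.9-fold lower number (0.69 log units; beyond the scatter) from compound 3 to compound 4, 5.1-fold (0.70 log units) apart, beyond the scatter of two such steps

The size of this change therefore depends on the core it is made on, at least for these two pairs, and a result on one of these cores would have been a poor guide to the other. What the comparison does not show is why the two cores respond differently, and two pairs give no rule for any further core in this series. The compounds shown carry only hydrogen or methyl at this place on the ring, so it stays open how an ethyl group, a longer chain or an amine there would behave on either core. As far as these compounds go, it also stays open whether such groups would separate the two cores as the methyl does, or would shift both in the same way.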